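The source may report more compounds than this note shows. Statements on the series, on what has been measured and on what is new or still open speak of the compounds shown alone.

Compound 2 `Cc1ccc(OCC(=O)NNC(=O)c2cc3ccccc3oc2=O)c(C(=O)c2ccccc2)c1` stands highest of the two numbers in a functional assay on Ehrlich cells (Mus musculus) for cytotoxicity, read by LDH release, with a stated time of 48 h; a higher number here means a weaker inhibitor, a lower number a stronger inhibitor: compound 2 gives 81100 nM, while compound 1 `Cc1ccc(OCC(=O)NNC(=O)c2cc3ccccc3oc2=O)c(C(=O)c2ccccc2Br)c1` gives 9400 nM. Going by the values given here, the single measured step, an 8.6-fold higher number from compound 1 to compound 2 (0.94 log units; beyond the scatter), is the only guide available. Compound 3 `Cc1ccc(OCC(=O)NNC(=O)c2cc3ccccc3oc2=O)c(C(=O)c2ccc(Cl)cc2)c1` differs from compound 2 by chloro in place of hydrogen on an aromatic carbon. The step from compound 1 to compound 2 concerns a bromo on the same six-membered aromatic ring of carbon only, though the chloro in compound 3 enters at a different place, para to a large group, so that step bears on the change only loosely. A chloro entering where a hydrogen left is therefore expected to lower the number in this assay, by less than the measured step seen in the other direction. Compound 3 is expected at 22000 nM, with a range from 7000 nM to 65000 nM, which corresponds to an expected step of a 3.7-fold lower number from compound 2 to compound 3 (0.57 log units; beyond the scatter).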

Compound 3, half-maximal inhibitory concentration: 58000 nM
Estimate against measurement, compound 3: 2.6-fold (0.42 log units) below; the range from low to high includes it.
By their numbers in this assay, from the lowest: compound 1; then compounds 3 and 2 (each within the scatter of the next).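

In this assay, chloro in place of hydrogen on an aromatic carbon, para to a large group, gives a 1.4-fold lower number from compound 2 to compound 3 (0.15 log units; within the scatter), so at this position the chloro leaves compound 3 indistinguishable from compound 2, and the halogen effect seen earlier does not carry over to this change. Set against the bromo compound, 4-chlorophenyl in place of 2-bromophenyl on a carbonyl carbon gives a 6.2-fold higher number from compound 1 to compound 3 (0.79 log units; beyond the scatter), leaving compound 1 alone apart from the other two, although this step changes both the halogen and its place on the ring. Nothing shown here explains these numbers.

Still open, going by these compounds, is whether the number follows the halogen or its place, which 4-bromophenyl and 2-chlorophenyl would separate. Also open, on these data alone, is how an amine or a carboxylic acid on this ring would read.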